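A Ring Swap on a Measured Starting Point

A few compounds are considered here, and "the series" means these few. Any claim that something is new, unique, unknown or untested is made for them only; others in the source may bear on it.

In a functional assay on DU-145 cells (Homo sapiens) for inhibition, read by trypan blue exclusion, with a stated time of 96 h (on this read-out higher numbers stand for weaker inhibition of growth and lower numbers for stronger inhibition of growth), compound 1 `O=C(O)c1cc(/C=C(\C(=O)c2c(F)c(F)c(F)c(F)c2F)S(=O)(=O)c2ccc(Br)cc2)ccc1O` gives > 100000 nM as a limit and not a number. Going by the values given here, compound 2 `COc1cc(/C=C(/Sc2ccc(Br)cc2)C(=O)c2ccc(Br)cc2)ccc1F` gives 10000 nM as the only exact number so far, so it has no measured neighbour to be ranked against. Compound 3 `O=C(/C(=C\c1ccc(F)cc1Cl)Sc1ccc(Br)cc1)c1ccc(Br)cc1` has 2-chloro-4-fluorophenyl in place of 4-fluoro-3-methoxyphenyl on a double-bonded chain carbon bound to a double-bonded chain carbon on a double-bonded chain carbon bound to a double-bonded chain carbon. With only compound 2 at 10000 nM to lean on, no shift beyond the usual scatter is expected in this assay in either direction. The expected result is no change at the digits printed from compound 2 to compound 3 (within the scatter) as a change. The estimate for compound 3 is 10000 nM with an expected range from 3000 nM to 40000 nM in this test.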

Compound 3, concentration for 50% growth inhibition: 1000 nM
For compound 3 the middle estimate is 10-fold (1.00 log units) above the measured one; the whole stated range lies above it.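

In this assay, putting 2-chloro-4-fluorophenyl in place of 4-fluoro-3-methoxyphenyl gives a 10-fold lower number from compound 2 to compound 3 (1.00 log units; beyond the scatter), which means stronger inhibition of growth. Going by these compounds alone, this is the only step that can be read so far, and it shows that a change of ring at this position can move the result beyond the usual scatter. Nothing measured here accounts for the gain. The swap adds a chlorine and removes a methoxy group together, and the compounds shown do not separate the two. Going by these compounds, how a ring carrying a dimethylamino group would behave at this position also remains open.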